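Swapping 1H-indol-3-yl for 4-(dimethylamino)phenyl: compound 3 to compound 4

The source may report more compounds than this note shows. Statements on the series, on what has been measured and on what is new or still open speak of the compounds shown alone.

Measured in a functional assay on MCF7 cells (Homo sapiens) for antiproliferative activity, read by MTT assay, with a stated time of 72 h; on this read-out higher numbers stand for weaker inhibition and lower numbers for stronger inhibition:
- compound 1 `C#CCSc1nc(N/N=C/c2ccc(N(C)C)cc2)c2nnn(Cc3ccccc3)c2n1`: > 64000 nM (a limit, not a number)
- compound 2 `CCCSc1nc(N/N=C/c2ccccc2Cl)c2nnn(Cc3ccccc3)c2n1`: 13800 nM
- compound 3 `CCCSc1nc(N/N=C/c2c[nH]c3ccccc23)c2nnn(Cc3ccccc3)c2n1`: 9010 nM

Among the compounds with values here, compound 3 gives 9010 nM, a value that cannot be separated from its one numbered neighbour: the measured step of a 1.5-fold lower number from compound 2 to compound 3 (0.19 log units; within the scatter) stays within the scatter. Compound 4 `CCCSc1nc(N/N=C/c2ccc(N(C)C)cc2)c2nnn(Cc3ccccc3)c2n1` puts 4-(dimethylamino)phenyl in place of 1H-indol-3-yl on a carbon with a double bond to nitrogen. Within the data shown here, that small step is the only measured swap at this place. Compound 1, with the same 4-(dimethylamino)phenyl on a different chain, reports only a limit, > 64000 nM. Together these suggest a modest move towards a higher number in this assay, and the expected size is a 2.2-fold higher number from compound 3 to compound 4 (0.35 log units; beyond the scatter). For compound 4 the estimated value is 20000 nM, with an expected range of 7000 nM to 60000 nM.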

Compound 4, half-maximal inhibitory concentration: 12200 nM
Beside the measured number, compound 4's estimate is 1.6-fold (0.21 log units) above it; the measured number falls inside the stated range.
By their numbers in this assay, from the lowest: compounds 3, 4 and 2 (each within the scatter of the next). At a limit, above all of these: compound 1.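

In this assay, 4-(dimethylamino)phenyl on a carbon with a double bond to nitrogen cannot be told apart from the other two groups there: the swaps give a 1.4-fold higher number from compound 3 to compound 4 (0.13 log units; within the scatter) and a 1.1-fold lower number from compound 2 to compound 4 (0.05 log units; within the scatter). The sulfur chain is where a difference can be read, as ethyl in place of ethynyl on a saturated chain carbon bound to a sulfur gives an at least 5.2-fold lower number from compound 1 to compound 4 (0.71 log units; beyond the scatter). Compound 1 stands at a limit, not a number: the limit of > 64000 nM in this assay, at which 1 of the 4 values shown sits.

Still open, on these data alone, is how a longer chain on the sulfur would read, and whether a carboxylic acid in place of these aromatic groups would give a step beyond the scatter.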